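This account rests on a few compounds, and the source may have more. Where it says the series, first, only, none or still open, it means among the compounds named here.

Compound 1, with the structure `COc1ccc(-c2nc3cc(-c4nc5cc(N6CCN(C)CC6)ccc5[nH]4)ccc3[nH]2)cc1`, is measured in a functional assay on RPMI 8402 cells (Homo sapiens) for cytotoxicity (on this read-out lower numbers stand for stronger inhibition and higher numbers for weaker inhibition), only as a limit. In this assay compound 1 gives < 50 nM, a limit of the assay and not a number. Compound 2, with the structure `COc1ccc(-c2nc3cc(-c4nc5cc(CCCN(C)C)ccc5[nH]4)ccc3[nH]2)cc1`, gives in this assay 1200 nM, the only number shown. Between the two there is the step of an at least 24-fold higher number from compound 1 to compound 2 (1.38 log units; beyond the scatter), in which a 3-(dimethylamino)propyl chain on an aromatic carbon replaces a 4-methylpiperazin-1-yl ring, as the evidence the limit of < 50 nM in this assay, at which 1 of the 2 values shown sits, notes for the limit. Compound 3, with the structure `COc1ccc(-c2nc3cc(-c4nc5cc(CN(C)C)ccc5[nH]4)ccc3[nH]2)cc1`, differs from compound 2 by dimethylamino in place of 2-(dimethylamino)ethyl on a saturated chain carbon bound to an aromatic carbon. Among the measured compounds shown here, only the step from compound 1 to compound 2 is known, and it exchanges a ring amine for a chain amine rather than shortening a chain, so it bears on the new step only loosely. A moderate move toward lower numbers is expected for compound 3, estimated as a 2.4-fold lower number from compound 2 to compound 3 (0.38 log units; beyond the scatter). Compound 3 is therefore estimated at 500 nM, with a range from 120 nM to 2000 nM.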

Compound 3, half-maximal inhibitory concentration: 380 nM
Compound 3: the middle estimate sits 1.3-fold (0.12 log units) above what was measured; low and high end bracket the measured number.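

In this assay, the group on the aromatic carbon now changes in chain length alone: going from 3-(dimethylamino)propyl to (dimethylamino)methyl gives a 3.2-fold lower number from compound 2 to compound 3 (0.50 log units; beyond the scatter). This shows that chain length at this position moves the number by a modest step beyond the scatter, which the earlier pair could not show, since it exchanged a ring amine for a chain amine. The shorter chain still does not reach the ring amine, as (dimethylamino)methyl in place of 4-methylpiperazin-1-yl gives an at least 7.6-fold higher number from compound 1 to compound 3 (0.88 log units; beyond the scatter). Compound 1 stands at a limit of the assay and not a number: the limit of < 50 nM in this assay, at which 1 of the 3 values shown sits.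

The compounds shown leave open how 2-(dimethylamino)ethyl directly on the aromatic carbon would read, and so whether the change with chain length runs evenly or is confined to the shortest chain. They also leave open whether the gain seen with 4-methylpiperazin-1-yl belongs to the ring as such, a question that a morpholine, a piperidine or an unsubstituted piperazine on the same aromatic carbon would address.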